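This account rests on a few compounds, and the source may have more. Where it says the series, first, only, none or still open, it means among the compounds named here.

Working notes on a three-compound set sharing one core, read in an ADME assay on Vero 76 cells (Chlorocebus sabaeus) for cytotoxicity, read by MTT assay, with a stated time of 96 h; a lower number here means that less compound is tolerated, a higher number that more compound is tolerated. Compound 1 `FC(F)(F)c1ccc(-c2nn(-c3ccccc3)cc2CNc2ccc(Cl)cc2)cc1` gives 10000 nM, compound 2 `FC(F)(F)c1ccc(NCc2cn(-c3ccccc3)nc2-c2ccc(Br)cc2)cc1` gives 28000 nM, and compound 3 `Cc1ccc(-c2nn(-c3ccccc3)cc2CNc2ccc(Br)cc2)cc1` gives 92000 nM. Compound 2 therefore stands second highest of the three, with compound 1 lower and compound 3 higher, and both gaps lie beyond the usual scatter.

Within the data shown here, no two measured compounds differ in only one place, so the set gives no direct size for a single substitution. The next compound to be read is compound 4 `FC(F)(F)c1ccc(NCc2cn(-c3ccccc3)nc2-c2ccc(Cl)cc2)cc1`. It departs from compound 2 at one place: chloro in place of bromo on an aromatic carbon. This puts chloro in place of bromo on an aromatic carbon, para to a large group, turning 4-bromophenyl into 4-chlorophenyl.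

The expected outcome in this assay is no step beyond the scatter, with no direction favoured. Among the measured compounds shown here, the estimate is anchored on compound 2 at 28000 nM, and the range is kept wide since no measured single-place step is available to calibrate it. The expected change, a 1.1-fold higher number from compound 2 to compound 4 (0.03 log units; within the scatter), is small. For compound 4 the estimated value is 30000 nM, with an expected range of 12000 nM to 75000 nM.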

Compound 4, half-maximal cytotoxic concentration: 18000 nM
Beside the measured number, compound 4's estimate is 1.7-fold (0.22 log units) above it, within the range that was stated.
By their numbers in this assay, from the lowest: compounds 1, 4 and 2 (each within the scatter of the next, the first and the last beyond it); then compound 3.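

In this assay, among these compounds, chloro in place of bromo on an aromatic carbon, para to a large group, gives the first single-place step (a 1.6-fold lower number from compound 2 to compound 4 (0.19 log units; within the scatter)). Among the compounds shown here, earlier compounds offered no such pair, so this step provides the only direct reading of a single change: in this pair, 4-bromophenyl and 4-chlorophenyl are not separated by the read-out, and the exchange of one halogen for the other leaves no difference that can be distinguished from repeat measurement. No supporting measurement bears on this result, and it offers no explanation for the step.

As far as these compounds go, whether a group of a different kind at this same place, such as an amine, a carboxylic acid or a methoxy group, would give a step beyond the scatter remains open. Also open, from the compounds shown here alone, is whether the same exchange would read alike with a different group on the other side of the shared core, since this single pair cannot show whether the result carries over to another setting.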